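The source may report more compounds than this note shows. Statements on the series, on what has been measured and on what is new or still open speak of the compounds shown alone.

Measured compounds:
- compound 1, `COC(=O)C1=C(C)N=C(C)/C(=C(\O)OC)C1c1ccc(Cl)cc1`, 8130 nM
- compound 2, `COC(=O)C1=C(C)N=C(C)/C(=C(\O)OC)C1c1c(Cl)cccc1Cl`, 1.91 nM
- compound 3, `COC(=O)C1=C(C)N=C(C)/C(=C(\O)OC)C1c1ccccc1C#N`, 15.9 nM

These three share one core and differ only in the aromatic ring attached to a saturated ring carbon. In a functional assay (muscle tissue) with Cavia porcellus as the target (on this read-out lower numbers stand for an effect already at smaller amounts and higher numbers for an effect only at larger amounts of compound), compound 2 gives the lowest number of the three: compound 3 stands nearest to it, as an 8.3-fold higher number from compound 2 to compound 3 (0.92 log units; beyond the scatter) shows, and compound 1 furthest, as a 4300-fold lower number from compound 1 to compound 2 (3.63 log units; beyond the scatter) shows when read in the opposite direction.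

Compound 4 is `COC(=O)C1=C(C)N=C(C)/C(=C(\O)OC)C1c1cccc(N)c1`, not yet measured. The change from compound 2 is 3-aminophenyl in place of 2,6-dichlorophenyl on a saturated ring carbon. For the measured compounds named here, two measured steps bear on this: a 4300-fold lower number from compound 1 to compound 2 (3.63 log units; beyond the scatter) tells that exchanging the 2,6-dichlorophenyl for a differently substituted phenyl can move the number very far, while an 8.3-fold higher number from compound 2 to compound 3 (0.92 log units; beyond the scatter) tells that a different substitution pattern still cost a modest amount. Going by the values given here, compound 4 carries neither the 2,6-dichlorophenyl of compound 2 nor the 2-cyanophenyl of compound 3, and no measured compound holds a 3-aminophenyl, so the size of its step is uncertain. A rise well beyond the scatter is expected, estimated as a 160-fold higher number from compound 2 to compound 4 (2.20 log units; beyond the scatter). For compound 4 the expected value in this assay is 300 nM, within 30 nM to 3000 nM.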

Compound 4, half-maximal effective concentration: 2000 nM
Compound 4: the middle estimate sits 6.7-fold (0.82 log units) below what was measured; the measured number falls inside the stated range.
By their numbers in this assay, from the lowest: compound 2; then compound 3; then compound 4; then compound 1.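

The 3-aminophenyl ring places compound 4 far from the two lowest numbers in this assay (a step of a 1000-fold higher number from compound 2 to compound 4 (3.02 log units; beyond the scatter) and one of a 130-fold higher number from compound 3 to compound 4 (2.10 log units; beyond the scatter)), which extends what compound 1 first suggested: at this saturated ring carbon, the choice of substituted phenyl can decide most of the outcome. Among these four compounds, the two lowest numbers belong to the rings named 2,6-dichlorophenyl and 2-cyanophenyl, both with a group at ring position 2, while the two highest belong to 3-aminophenyl and 4-chlorophenyl, and no compound here goes against that grouping, although four compounds make only a narrow basis for it. The two high compounds are not equal, however (a step of a 4.1-fold lower number from compound 1 to compound 4 (0.61 log units; beyond the scatter)), and no measurement at hand gives a reason for any of these steps.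

Going by these compounds, what remains open is whether the ring position of the substituent or the identity of the group matters more, since the same group is never compared at two ring positions here. A 2-aminophenyl or a 3-chlorophenyl at this carbon would separate those two factors, and a 2-chlorophenyl would show what the second chlorine of compound 2 contributes.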